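Hydroxyethyl Amide Variant of a Pyrazolopyridine GIP Receptor Agonist

The source may report more compounds than this note shows. Statements on the series, on what has been measured and on what is new or still open speak of the compounds shown alone.

Compound 1: `CC(C)OC(=O)N1CCC(n2ncc3cc(-c4cc(F)c(C(N)=O)cc4F)ncc32)CC1` — 52 nM
Compound 2: `CC(C)OC(=O)N1CCC(n2ncc3cc(-c4cc(F)c(C(=O)N(C)C)cc4F)ncc32)CC1` — 46 nM
Compound 3: `CCCNC(=O)c1cc(F)c(-c2cc3cnn(C4CCN(C(=O)OC(C)C)CC4)c3cn2)cc1F` — 14 nM

Three compounds sharing a common core were measured in a functional assay on HEK293 cells for agonist activity at Glucose-dependent insulinotropic receptor (Homo sapiens), read by cAMP accumulation, with a stated time of 30 min; a higher number here means that more compound is needed for the effect, a lower number that less compound is needed. Compound 1 gives 52 nM and compound 2 gives 46 nM; the step of a 1.1-fold lower number from compound 1 to compound 2 (0.05 log units; within the scatter) lies within the scatter. Compound 3 stands lowest of the three, with 14 nM, separated from the others by the steps of a 3.7-fold lower number from compound 1 to compound 3 (0.57 log units; beyond the scatter) and a 3.3-fold lower number from compound 2 to compound 3 (0.52 log units; beyond the scatter), both beyond the scatter.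

Compound 4, `CC(C)OC(=O)N1CCC(n2ncc3cc(-c4cc(F)c(C(=O)NCCO)cc4F)ncc32)CC1`, differs from compound 3 in one place: hydroxy in place of methyl on a saturated chain carbon, two bonds along the chain from an amide-type nitrogen. Going by the values given here, no measured step exchanges a methyl for a hydroxy, so none bears directly on this change. The steps from compound 1 and compound 2 to compound 3 show that the chain on the amide nitrogen matters to a modest degree, so replacing its end carbon is expected to move the number modestly, most likely upward toward compound 1. The estimated step is a 2.1-fold higher number from compound 3 to compound 4 (0.33 log units; beyond the scatter). Compound 4 is therefore estimated at 30 nM, within a range of 12 nM to 80 nM.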

Compound 4, half-maximal effective concentration: 92 nM
Beside the measured number, compound 4's estimate is 3.1-fold (0.49 log units) below it, and the stated range ends below it.
By their numbers in this assay, from the lowest: compound 3; then compounds 2, 1 and 4 (each within the scatter of the next).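

In this assay, hydroxy in place of methyl on a saturated chain carbon, two bonds along the chain from an amide-type nitrogen, gives a 6.6-fold higher number from compound 3 to compound 4 (0.82 log units; beyond the scatter), so this position responds to the change and the advantage of compound 3 does not carry over to a 2-hydroxyethyl chain. Compound 4 cannot be told apart from the earlier amides, with a 1.8-fold higher number from compound 1 to compound 4 (0.25 log units; within the scatter) and a 2.0-fold higher number from compound 2 to compound 4 (0.30 log units; within the scatter), so a chain on the amide nitrogen does not by itself give the lower number of compound 3. No available evidence accounts for this step.

The compounds shown leave open whether a methoxy or an amine at this place would behave like hydroxy or like methyl. They also leave open how a butyl chain on the amide nitrogen would compare with propyl.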